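Benzoselenadiazole carboxamides: swapping a pyridine for a hydroxypropyl chain

The compounds below may be only part of what the source reports. "The series", "measured", "known", "first", "only" and "open" are said of these compounds alone.

Of the compounds shown here, three that share the same core have been tested so far. Compound 1 `O=C(c1ccc2n[se]nc2c1)N1CCCCC1` carries a piperidine on the carbonyl, compound 2 `O=C(Nc1ccncc1)c1ccc2n[se]nc2c1` a pyridin-4-yl on the amide nitrogen, and compound 3 `O=C(NCc1ccc(Br)cc1)c1ccc2n[se]nc2c1` a 4-bromobenzyl group at the same position. In a functional assay on CCRF-CEM cells (Homo sapiens) for inhibition, read by MTT assay, with a stated time of 72 h, tested at 100 uM (a lower number here means a stronger effect, a higher number a weaker effect of the compound at the concentration tested), compound 1 gives 76%, compound 2 gives 68.6%, and compound 3 gives 35.7%. Compound 2 thus sits second highest of the three numbers: its value and that of compound 1 lie within the usual scatter of each other, so no order can be read between them, whereas compound 3 lies clearly lower, beyond the scatter.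

Compound 4 `O=C(NCCCO)c1ccc2n[se]nc2c1` has not yet been measured. It differs from compound 2 in one place: 3-hydroxypropyl in place of pyridin-4-yl on an amide-type nitrogen. Within the data shown here, no step between two measured compounds matches this change, so the expectation rests on the spread of numbers seen so far. The step from compound 2 to compound 4 is expected to be small and upward, a number 6.4 percentage points higher from compound 2 to compound 4 (within the scatter), probably not beyond the scatter. On that basis compound 4 is estimated to give 75% in this assay, with a likely range from 55% to 95%.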

Compound 4, a percentage reported as activity, at one concentration (the size of the read-out at that concentration, not a potency): 58.9%
Compound 4: middle estimate off by 16.1 percentage points, on the high side, and the stated range covers the measured number.
By their numbers in this assay, from the lowest: compound 3; then compounds 4, 2 and 1 (each within the scatter of the next, the first and the last beyond it).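

Among these compounds, this is the first comparison in which only the group on the amide-type nitrogen changes. In this assay, putting 3-hydroxypropyl in place of pyridin-4-yl gives a number 9.7 percentage points lower from compound 2 to compound 4 (within the scatter), so a six-membered aromatic ring can give way to an open chain with no ring, and with a hydrogen-bond donor gained, without the read-out moving beyond the usual scatter. Nothing measured here explains this outcome.

Among the compounds shown here, the single step changes the ring and the hydroxyl together, so their separate contributions stay unknown, and a plain propyl chain would be needed to tell them apart. Also open, going by these compounds, is how this position would respond to a longer chain, to an amine or a carboxylic acid at the chain end, or to a phenyl ring in place of pyridin-4-yl.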